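This account rests on a few compounds, and the source may have more. Where it says the series, first, only, none or still open, it means among the compounds named here.

Measured in a toxicity assay on HEK-293T cells (Homo sapiens) for cytotoxicity, read by MTT assay, with a stated time of 72 h; on this read-out lower numbers stand for stronger inhibition and higher numbers for weaker inhibition:
- compound 1 `O=C1c2c[n+]([O-])c3ccccc3c2C(=O)c2c1c1ccccc1n2Cc1cn(CC(O)CO)nn1`: 760 nM
- compound 2 `CC1(C)OC[C@H](Cn2cc(Cn3c4c(c5ccccc53)C(=O)c3c[n+]([O-])c5ccccc5c3C4=O)nn2)O1`: 100 nM
- compound 3 `CC1(C)OC[C@@H](Cn2cc(Cn3c4c(c5ccccc53)C(=O)c3c[n+]([O-])c5ccccc5c3C4=O)nn2)O1`: 6020 nM

Compound 1 holds the middle place among these numbers, with a 7.6-fold lower number from compound 1 to compound 2 (0.88 log units; beyond the scatter) on one side and a 7.9-fold higher number from compound 1 to compound 3 (0.90 log units; beyond the scatter) on the other. The large 60-fold higher number from compound 2 to compound 3 (1.78 log units; beyond the scatter) goes with the fact that compounds 2 and 3 differ only in the configuration as drawn.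

Compound 4 `O=C1c2c[n+]([O-])c3ccccc3c2C(=O)c2c1c1ccccc1n2CCCN1CCC(O)CC1` changes the side chain of compound 1: 2-(4-hydroxypiperidin-1-yl)ethyl in place of 1-(2,3-dihydroxypropyl)-1H-1,2,3-triazol-4-yl on a saturated chain carbon bound to an aromatic nitrogen. The steps measured so far replace only the 1,2-dihydroxyethyl group, not the whole 1-(2,3-dihydroxypropyl)-1H-1,2,3-triazol-4-yl group, so they bear on this change only indirectly. They are modest in size and run in opposite directions, so they set no direction. In this assay, no step beyond the scatter is therefore expected, although a modest step either way would not surprise. The estimated step is a 1.5-fold lower number from compound 1 to compound 4 (0.18 log units; within the scatter). The expected value for compound 4 is 500 nM, within an estimated range of 100 nM to 4000 nM.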

Compound 4, half-maximal inhibitory concentration: 170 nM
Beside the measured number, compound 4's estimate is 2.9-fold (0.47 log units) above it; measured number inside the range.
By their numbers in this assay, from the lowest: compounds 2 and 4 (each within the scatter of the next); then compound 1; then compound 3.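

Compound 4 shows that this position, on a saturated chain carbon bound to an aromatic nitrogen, can lose the whole 1-(2,3-dihydroxypropyl)-1H-1,2,3-triazol-4-yl group and not only its 1,2-dihydroxyethyl end. In this assay, putting 2-(4-hydroxypiperidin-1-yl)ethyl there gives a 4.5-fold lower number from compound 1 to compound 4 (0.65 log units; beyond the scatter), so the number moves beyond the scatter with no aromatic triazole ring in the side chain. Nothing in the available evidence accounts for this step.

The replacement changes the ring, the chain and the hydroxyl groups all at once, and the compounds shown do not separate what each contributes to the step. As far as these compounds go, how a plain piperidine, a morpholine or a longer chain at this position would read in this assay remains open.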